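Swapping dimethylcarbamoyl for 1,3-oxazol-4-yl in compound 2

The source may hold more compounds than are shown below. What is called first, only, known or untested is meant among the compounds shown, and "the series" means these compounds.

Measured so far in an ADME assay on the whole organism (plasma, strain 129/SvEvBrd x C57BL/6) for pharmacokinetics, with Mus musculus as the target, at a dose of 10 mg/kg by the oral route; a lower number here means less compound in the circulation, a higher number more compound in the circulation at the dose given:
- compound 1 `CC(=O)c1cccc([C@@H](O)[C@H](O)[C@H](O)CO)n1`: 10500 ng.h/mL
- compound 2 `CN(C)C(=O)c1nc([C@@H](O)[C@H](O)[C@H](O)CO)c[nH]1`: 1740 ng.h/mL

Compound 2 has the lower of these two numbers, and the gap up to compound 1 lies beyond the usual scatter of repeated measurements. Compound 3 `OC[C@@H](O)[C@@H](O)[C@H](O)c1c[nH]c(-c2cocn2)n1` has not been measured yet. It differs from compound 2 in one place: 1,3-oxazol-4-yl in place of dimethylcarbamoyl on an aromatic carbon. In short, 1,3-oxazol-4-yl stands in place of dimethylcarbamoyl on an aromatic carbon. Within the data shown here, no measured pair shows what this swap does in this assay, so any expectation is loose. The main anchor is compound 2 at 1740 ng.h/mL, while compound 1 at 10500 ng.h/mL shows that a higher number is possible among these compounds. A small upward move that stays within the scatter is expected, a 1.4-fold higher number from compound 2 to compound 3 (0.16 log units; within the scatter). Compound 3 is estimated at 2500 ng.h/mL, with an expected range of 700 ng.h/mL to 9000 ng.h/mL.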

Compound 3, area under the concentration-time curve: 868 ng.h/mL
Beside the measured number, compound 3's estimate is 2.9-fold (0.46 log units) above it; the range from low to high includes it.
By their numbers in this assay, from the lowest: compounds 3 and 2 (each within the scatter of the next); then compound 1.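

In this assay, placing 1,3-oxazol-4-yl on the aromatic carbon between two ring nitrogen atoms gives a 2.0-fold lower number from compound 2 to compound 3 (0.30 log units; within the scatter), so this read-out does not tell the two groups apart. Dimethylcarbamoyl has no ring and 1,3-oxazol-4-yl is a five-membered aromatic ring, each with 5 heavy atoms, so this one pair shows that a ring can stand at this place without a step beyond the usual scatter. Nothing available explains the result.

Still open, going by these compounds, is whether a different group at this place, such as a primary amide, a carboxylic acid or an amine, would move the number beyond the scatter. On these data alone, it is also open whether the same swap would behave alike if the group of 8 heavy atoms on the shared core were changed.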